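The source may report more compounds than this note shows. Statements on the series, on what has been measured and on what is new or still open speak of the compounds shown alone.

Compound 2 `CN1CCCN(c2cncc(-c3cc(CCO)no3)c2)CC1` gives 51.4 nM in an assay on a protein complex for displacement of a labelled ligand from Neuronal acetylcholine receptor; alpha4/beta2 (Rattus norvegicus), read by scintillation counting (a lower number here means a stronger inhibitor, a higher number a weaker inhibitor), the highest number of the three measured compounds. Compound 1 `COCC[C@H]1C[C@@H]1c1cncc(N2CCCNCC2)c1` gives 0.7 nM and compound 3 `COCC[C@@H]1C[C@H]1c1cncc(N2CCCNCC2)c1` gives 0.5 nM. Within the data shown here, the one measured step, from compound 1 to compound 3, is a 1.4-fold lower number from compound 1 to compound 3 (0.15 log units; within the scatter) and rests only on (the fact that compounds 1 and 3 differ only in the configuration as drawn), so it says nothing about the change considered here. Compound 4 `OCCc1cc(-c2cncc(N3CCCNCC3)c2)on1` differs from compound 2 by hydrogen in place of methyl on an amine nitrogen in a ring. Among the measured compounds shown here, no measured step covers this change, so the expectation leans on the values alone: compound 1 at 0.7 nM and compound 3 at 0.5 nM both carry hydrogen on the ring amine nitrogen and sit far lower than compound 2. Compound 4 is therefore estimated at 8 nM, within 1.5 nM to 40 nM, an expected step of a 6.4-fold lower number from compound 2 to compound 4 (0.81 log units; beyond the scatter).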

Compound 4, inhibition constant: 0.8 nM
The estimate for compound 4 lay 10-fold (1.00 log units) above the measured number, and the stated range ends above it.
By their numbers in this assay, from the lowest: compounds 3, 1 and 4 (each within the scatter of the next); then compound 2.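

In this assay, among these compounds, hydrogen in place of methyl on the ring amine nitrogen gives a 64-fold lower number from compound 2 to compound 4 (1.81 log units; beyond the scatter), the first direct reading of this change. The two compounds differ in that one place only, so this single swap accounts for the whole large step between them. Nothing measured here explains why the step is so large.

Going by these compounds, whether an ethyl or a longer chain on this nitrogen would behave like methyl remains open. So does whether methyl would give a step of similar size on the core of compound 1.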